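This account rests on a few compounds, and the source may have more. Where it says the series, first, only, none or still open, it means among the compounds named here.

Compounds measured so far in an assay on HEK293 cells for agonist activity at transient receptor potential cation channel subfamily M member 8 (Homo sapiens), read by fluorescence and calcium flux, with a stated time of 15 min; a lower number here means that less compound is needed, a higher number that more compound is needed for the effect:

Compound 1, `Cc1ccc(OCC(=O)N(CCCO)Cc2cccs2)cc1`: 3000 nM
Compound 2, `C=CCN(Cc1cccs1)C(=O)COc1ccc(C)cc1`: 20 nM
Compound 3, `Cc1ccc(OCC(=O)N(Cc2cccs2)c2ccncc2)cc1`: 52 nM

Compound 3 holds the second lowest of these three numbers; compound 2 sits close by, since a 2.6-fold higher number from compound 2 to compound 3 (0.41 log units; beyond the scatter), while compound 1 lies far off, since a 58-fold lower number from compound 1 to compound 3 (1.76 log units; beyond the scatter). Compound 4, `Cc1ccc(OCC(=O)N(Cc2cccs2)c2cccnc2)cc1`, keeps every atom of compound 3 and rearranges only the attachment of the ring on the amide-type nitrogen: pyridin-3-yl in place of pyridin-4-yl on an amide-type nitrogen. Going by the values given here, no measured step swaps one pyridine isomer for another. The nearest guide is the modest step from allyl to pyridin-4-yl, a 2.6-fold higher number from compound 2 to compound 3 (0.41 log units; beyond the scatter), which suggests this nitrogen position tolerates variation without large shifts. Compound 4 is therefore expected to land near compound 3, with a 1.2-fold higher number from compound 3 to compound 4 (0.06 log units; within the scatter) as a step, giving an estimated 60 nM within the range 20 nM to 180 nM.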

Compound 4, half-maximal effective concentration: 198 nM
The estimate for compound 4 lay 3.3-fold (0.52 log units) below the measured number; measured number outside the range, above it.
By their numbers in this assay, from the lowest: compound 2; then compound 3; then compound 4; then compound 1.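

In this assay, the two pyridine isomers are not interchangeable at this amide-type nitrogen (a 3.8-fold higher number from compound 3 to compound 4 (0.58 log units; beyond the scatter)), even though the counts of atoms, donors and acceptors are identical. Pyridin-3-yl gives a higher number than allyl (a 9.9-fold higher number from compound 2 to compound 4 (1.00 log units; beyond the scatter)) but a lower one than 3-hydroxypropyl (a 15-fold lower number from compound 1 to compound 4 (1.18 log units; beyond the scatter)), so compound 4 ranks between them. Thus, the attachment point of the ring alone can shift the number beyond the scatter.

From the compounds shown here alone, whether pyridin-2-yl or a plain phenyl ring would give a lower or higher number here remains open. Nothing available explains why the attachment point matters.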